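The source may hold more compounds than are shown below. What is called first, only, known or untested is meant among the compounds shown, and "the series" means these compounds.

Working notes on the series. The core of compound 1 `C/C(=N\CCO)c1c(O)c2ccccc2[nH]c1=O` carries a 2-hydroxyethyl chain. In an assay on isolated protein for inhibition of myosin-2 (Bos taurus), read by spectrophotometry, with a stated time of 24 min (a higher number here means a weaker inhibitor, a lower number a stronger inhibitor), compound 1 gives >= 100000 nM, which is a limit of the assay and not a number. Compound 1 thus stands at the limit of >= 100000 nM in this assay, at which 1 of the 2 values shown sits, so only a floor, not a position, is known for it. Among the measured compounds shown here, compound 2 `C/C(=N\CCCO)c1c(O)c2ccccc2oc1=O` differs from compound 1 in more than one place and no single step joins them; in this assay compound 2 gives 37000 nM, a measured number rather than a limit. Compound 3 `CCC/N=C(\C)c1c(O)c2ccccc2[nH]c1=O` is not yet measured in this assay and is reached from compound 1 by methyl in place of hydroxy on a saturated chain carbon, two bonds along the chain from a double-bonded nitrogen. For the measured compounds named here, no measured pair in the set shares this change, so nothing here sets its size or direction. The working expectation is a number no higher from compound 1 to compound 3 (the limit leaves the size open), that is, no movement beyond the scatter from a compound already at the limit. Compound 3 is accordingly estimated at 100000 nM, with a range of 25000 nM to 400000 nM, and a real chance that only a limit is reported again.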

Compound 3, half-maximal inhibitory concentration: >= 100000 nM
Compound 3: no number, only a limit (the forecaster's own chance of this, stated with the estimate: 60%); the middle value lies on the limit itself.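

In this assay, compound 1 and compound 3 both return limits of the assay and not numbers, so no step can be read between them: the limit of >= 100000 nM in this assay, at which 2 of the 3 values shown sit.

The compounds shown leave open the size and direction of any effect in this assay of going from 2-hydroxyethyl to propyl on the shared core.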